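Sulfur in place of an amine linker on the shared core

A few compounds are considered here, and "the series" means these few. Any claim that something is new, unique, unknown or untested is made for them only; others in the source may bear on it.

Of the compounds shown here, three built on one shared core have been measured so far. Compound 1 `Nc1cc(N)c2nc(-c3ccccc3)c(NCc3ccc(Cl)c(Cl)c3)nc2c1` gives 55000 nM in a functional assay on SF-268 cells (Homo sapiens) for inhibition, read by sulforhodamine B assay, with a stated time of 48 h; on this read-out lower numbers stand for stronger inhibition of growth and higher numbers for weaker inhibition of growth. Compound 3 `Nc1cc(N)c2nc(-c3ccccc3)c(NCc3ccc(F)cc3)nc2c1` gives 7590 nM in this assay. Compound 2 `CCOC(=O)[C@H](CCC(=O)O)NC(=O)c1ccc(Oc2nc3cc(N)cc(N)c3nc2-c2ccccc2)cc1` is reported in this assay only as a limit, < 100000 nM, not as a number. Going by the values given here, the one step between two measured compounds that differ in a single place is a 7.2-fold lower number from compound 1 to compound 3 (0.86 log units; beyond the scatter), and it concerns only the substitution pattern on the ring of the benzyl group. Compound 3 therefore stands at the lowest of the two numbers in this assay, with compound 1 the nearest at a clearly higher number.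

Compound 4 `Nc1cc(N)c2nc(-c3ccccc3)c(Sc3ccc(F)cc3)nc2c1` differs from compound 3 by (4-fluorophenyl)sulfanyl in place of (4-fluorobenzyl)amino on an aromatic carbon. Among the compounds with values here, no measured step bears on this kind of change: the only step concerned the ring substituent, not the linker between the ring and the core, so there is no direct guide. The estimate for compound 4 therefore rests on compound 3 alone and allows for a modest step in either direction; the expected step is a 2.0-fold higher number from compound 3 to compound 4 (0.30 log units; within the scatter). Compound 4 is estimated at 15000 nM in this assay, with a range from 4000 nM to 60000 nM.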

Compound 4, concentration for total growth inhibition: 38900 nM
Estimate against measurement, compound 4: 2.6-fold (0.41 log units) below; measured number inside the range.
By their numbers in this assay, from the lowest: compound 3; then compounds 4 and 1 (each within the scatter of the next).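

Going by these compounds alone, this is the first measured change in the link between the fluorinated ring and the shared core, rather than on the ring itself. In this assay, (4-fluorophenyl)sulfanyl in place of (4-fluorobenzyl)amino on this aromatic carbon gives a 5.1-fold higher number from compound 3 to compound 4 (0.71 log units; beyond the scatter), so the link matters here as well as the substituents on the ring, and the amine link gives the lower number in this one pair. The swap changes several things at once, since the entering group has a sulfur in place of the nitrogen, lacks the saturated chain carbon and carries 0 hydrogen-bond donors against 1 in the group that leaves, and nothing measured here bears on why the number rises.

The compounds shown leave open whether the step follows the sulfur or the lost chain carbon; a (4-fluorophenyl)amino group and a (4-fluorobenzyl)sulfanyl group on this carbon would pull those two apart. Also open, from the compounds shown here alone, is whether a sulfur link would give a step of similar size and direction with the 3,4-dichlorophenyl ring of compound 1.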